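Sulfonyl-bound amine variation: compound 3 estimate

A few compounds are considered here, and "the series" means these few. Any claim that something is new, unique, unknown or untested is made for them only; others in the source may bear on it.

Two compounds are measured in an assay on isolated protein for inhibition of 5-hydroxytryptamine receptor 4 (Homo sapiens); a higher number here means a weaker inhibitor, a lower number a stronger inhibitor. Compound 1 `O=C(NCC1CCN(CCCS(=O)(=O)N2CCN(c3ccccn3)CC2)CC1)c1cccc2c1OCCO2` gives 0.251 nM. Within the data shown here, compound 2 `CCCC1CCN(S(=O)(=O)CCCN2CCC(CNC(=O)c3cccc4c3OCCO4)CC2)CC1` gives 0.0631 nM, the lowest of the two numbers; the single step between them, a 4.0-fold lower number from compound 1 to compound 2 (0.60 log units; beyond the scatter), came from a swap of the group on the sulfonyl sulfur. Compound 3 `O=C(NCC1CCN(CCCS(=O)(=O)N2CCN(C3CCCC3)CC2)CC1)c1cccc2c1OCCO2` is not yet measured and differs from compound 2 by 4-cyclopentylpiperazin-1-yl in place of 4-propylpiperidin-1-yl on a sulfonyl sulfur. Among the measured compounds shown here, only the step from compound 1 to compound 2 concerns this position, and it was modest though beyond the scatter. Compound 3 shares the six-membered ring with two hetero atoms on the sulfonyl sulfur with compound 1, yet carries a non-aromatic carbon ring on it, so it is placed between the two measured values. Compound 3 is therefore expected to show a 2.4-fold higher number from compound 2 to compound 3 (0.38 log units; beyond the scatter). The estimate for compound 3 is 0.15 nM, with a range from 0.04 nM to 0.6 nM.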

Compound 3, inhibition constant: 0.0159 nM
Compound 3: middle estimate off by 9.4-fold (0.97 log units), on the high side; measured number below the stated range.
By their numbers in this assay, from the lowest: compound 3; then compound 2; then compound 1.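

Working notes on the group on the sulfonyl sulfur: in this assay, a nitrogen-bearing ring of the kind in compound 1 does not by itself limit this position, since 4-cyclopentylpiperazin-1-yl gives a lower number than 4-propylpiperidin-1-yl (a 4.0-fold lower number from compound 2 to compound 3 (0.60 log units; beyond the scatter)). The group on the amine nitrogen in that ring matters strongly: cyclopentyl in place of pyridin-2-yl is a single change and gives a large step (a 16-fold lower number from compound 1 to compound 3 (1.20 log units; beyond the scatter)). No available evidence explains either step.

From the compounds shown here alone, the step from compound 2 to compound 3 changes both the ring and its substituent, so their separate contributions stay open. Comparison with 4-cyclopentylpiperidin-1-yl or 4-propylpiperazin-1-yl would separate them, while cyclohexyl or isopropyl on the same nitrogen would test how far the cyclopentyl result extends.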